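Notes on the chain at the aromatic nitrogen

This account rests on a few compounds, and the source may have more. Where it says the series, first, only, none or still open, it means among the compounds named here.

Compound 1 `COc1cc(C(=O)c2ccc3c(ccn3C)c2)cc(OC)c1OC`: 14.1 nM
Compound 2 `COc1cc(C(=O)c2ccc3c(ccn3CO)c2)cc(OC)c1OC`: 39 nM

Both values come from a functional assay on NCI-H460 cells (Homo sapiens) for inhibition, with a stated time of 72 h; a lower number here means a stronger inhibitor, a higher number a weaker inhibitor. Compound 2, at 39 nM, has the higher number of the two and is the weaker inhibitor, the gap being a 2.8-fold higher number from compound 1 to compound 2 (0.44 log units; beyond the scatter).

Next in the series is compound 3 `COc1cc(C(=O)c2ccc3c(ccn3CCN(C)C)c2)cc(OC)c1OC`, which differs from compound 2 as follows: (dimethylamino)methyl in place of hydroxy on a saturated chain carbon bound to an aromatic nitrogen. In words, this is (dimethylamino)methyl in place of hydroxy on a saturated chain carbon bound to an aromatic nitrogen. Cut one bond further out, it reads hydroxymethyl to 2-(dimethylamino)ethyl.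

Going by the values given here, only one measured step bears on this place: a 2.8-fold higher number from compound 1 to compound 2 (0.44 log units; beyond the scatter). It was modest but beyond the scatter, and it ran towards a weaker inhibitor. Among the compounds with values here, no measured compound carries a dimethylamino group, so the direction rests on thin evidence and the range is kept wide. In this assay, a modest move towards a higher number is expected, estimated as a 2.3-fold higher number from compound 2 to compound 3 (0.36 log units; beyond the scatter). For compound 3 the expected value is 90 nM, with an estimated range of 25 nM to 320 nM.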

Compound 3, half-maximal inhibitory concentration: 5100 nM
Beside the measured number, compound 3's estimate is 57-fold (1.75 log units) below it; the whole stated range lies below it.
By their numbers in this assay, from the lowest: compound 1; then compound 2; then compound 3.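

In this assay the position proves far more sensitive than the first pair suggested: the change to 2-(dimethylamino)ethyl gives a 130-fold higher number from compound 2 to compound 3 (2.12 log units; beyond the scatter) and, set against the methyl chain of the first compound, a 360-fold higher number from compound 1 to compound 3 (2.56 log units; beyond the scatter) on the same shared core. The hydroxy change on this chain carbon, a 2.8-fold higher number from compound 1 to compound 2 (0.44 log units; beyond the scatter), therefore marks only a small part of the span this place can reach, and the three compounds now run in the order compound 1, compound 2, compound 3, with every step beyond the scatter. Nothing at hand explains the size of the large steps.

The compounds shown leave open whether the drop follows the dimethylamino group itself or the longer chain, as compound 3 differs in both at once; a plain ethyl or a 2-hydroxyethyl group at this place would separate the two. Also open, from the compounds shown here alone, is whether a carboxylic acid or a morpholine ring at the end of the same chain would track with the dimethylamino group or stay nearer the methyl and hydroxymethyl chains.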